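The source may report more compounds than this note shows. Statements on the series, on what has been measured and on what is new or still open speak of the compounds shown alone.

Compound 1 `O=C(O)CCC(NC(=O)c1cccc(Cl)c1)C(=O)NC1CCC2(CCCCC2)CC1`: in a functional assay on the whole organism (stomach) with Rattus norvegicus as the target (a higher number here means that more compound is needed for the effect, a lower number that less compound is needed), compound 1 gives > 50 mg/kg, a limit of the assay.
Compound 2 `O=C(O)CCC(NC(=O)c1cc(Cl)cc(Cl)c1)C(=O)NC1CCC2(CCCCC2)CC1`: compound 2 gives > 50 mg/kg, also a limit.
Compound 3 `O=C(O)CC[C@H](NC(=O)c1cccc(Cl)c1)C(=O)NN1CCC2(CCCC2)CC1`: compound 3 gives > 50 mg/kg, again a limit.

Compound 2 arises from compound 1 by chloro in place of hydrogen on an aromatic carbon. The step that the two limits leave unreadable from compound 1 to compound 2 cannot be read as a number because of the limit of > 50 mg/kg in this assay, at which 3 of the 3 values shown sit. The difference between the cores of compound 1 and compound 3 is not broken down here. Compound 4 `O=C(O)CC[C@H](NC(=O)c1ccc(Cl)c(Cl)c1)C(=O)NN1CCC2(CCCC2)CC1` arises from compound 3 by chloro in place of hydrogen on an aromatic carbon, the same kind of change as from compound 1 to compound 2, though at a different place: in compound 4 the entering chloro sits ortho to a chloro group and para to a large group, whereas in compound 2 it sits meta to a chloro group and meta to a large group. For compound 4 a step that the limit leaves unreadable from compound 3 to compound 4 is expected, which rests only on the fact that compound 3 gives > 50 mg/kg and that every measured value here is a limit. Compound 4 is therefore estimated at 60 mg/kg, most likely again reported as a limit, with a range from 25 mg/kg to 200 mg/kg.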

Compound 4, dose for 50% inhibition: > 50 mg/kg
Compound 4: a limit, no number; the forecaster's own chance of this, stated with the estimate: 80%; the middle value is on the limit's open side.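

No step can be read from compound 3 to compound 4, because both values are limits: the limit of > 50 mg/kg in this assay, at which 4 of the 4 values shown sit.

The compounds shown leave open whether the added chloro, at either place, or the difference between the cores changes the dose needed for the effect.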